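A methyl added to compound 2

A few compounds are considered here, and "the series" means these few. Any claim that something is new, unique, unknown or untested is made for them only; others in the source may bear on it.

compound 1 (`Cc1cn2c(/C=N/NC(=N)N)c(-c3ccsc3)nc2s1`): 46800 nM
compound 2 (`N=C(N)N/N=C/c1c(-c2cccs2)nc2sccn12`): 38000 nM

In a functional assay on cells (Leukemia cell, Homo sapiens) for inhibition (a lower number here means a stronger inhibitor of growth, a higher number a weaker inhibitor of growth), compound 2 gives 38000 nM and compound 1 gives 46800 nM, so the two numbers lie within the usual scatter of each other and neither stands apart.

Compound 3 (`Cc1cn2c(/C=N/NC(=N)N)c(-c3cccs3)nc2s1`) has not yet been measured. It differs from compound 2 in one place: methyl in place of hydrogen on an aromatic carbon, next to the ring sulfur of the five-membered aromatic ring with 1 nitrogen and 1 sulfur.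

Among the compounds with values here, no two measured compounds differ in one place only, so the effect of this methyl in this assay has not been seen on its own. Compound 1, which also carries a methyl but differs elsewhere too, gives 46800 nM, within the scatter of compound 2. No shift beyond the scatter is therefore expected in either direction. The estimated step of a 1.1-fold higher number from compound 2 to compound 3 (0.02 log units; within the scatter) is expected to stay within the scatter. Compound 3 is expected at 40000 nM, with an estimated range from 22000 nM to 72000 nM.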

Compound 3, concentration for total growth inhibition: 4070 nM
Beside the measured number, compound 3's estimate is 9.8-fold (0.99 log units) above it, outside the stated range (below it).
By their numbers in this assay, from the lowest: compound 3; then compounds 2 and 1 (each within the scatter of the next).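

In this assay, the methyl on the aromatic carbon next to the ring sulfur of the five-membered aromatic ring with 1 nitrogen and 1 sulfur can now be read on its own, as a 9.3-fold lower number from compound 2 to compound 3 (0.97 log units; beyond the scatter), so with thiophen-2-yl in place this position responds clearly to a single added carbon. The methyl alone does not account for the lower number, however: with the methyl held constant, thiophen-2-yl in place of thiophen-3-yl gives an 11-fold lower number from compound 1 to compound 3 (1.06 log units; beyond the scatter), so the attachment point of the thiophene also matters in the methyl-bearing series. No measurement available here bears on why either change has this effect.

The compounds shown leave open whether the methyl would produce a comparable step with thiophen-3-yl in place, so it cannot yet be said whether the two changes act independently or only in combination. They also leave open how far this position tolerates other groups, such as an ethyl chain, a chlorine atom or a hydroxymethyl group, and so whether the step is particular to methyl.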